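The source may report more compounds than this note shows. Statements on the series, on what has been measured and on what is new or still open speak of the compounds shown alone.

Compound 1, `N#CC1CN1C(=O)Nc1ccc(F)cc1`, is a cyanoaziridine urea in which the urea nitrogen carries an aromatic ring bearing a fluoro group. In a functional assay on WiDr cells (Homo sapiens) for inhibition (a lower number here means a stronger inhibitor, a higher number a weaker inhibitor), compound 1 gives 2100 nM. Its companion, compound 2, `N#CC1CN1C(=O)NC1CCCCC1`, replaces the aromatic ring with a saturated carbocycle; in this assay compound 2 gives 2400 nM. Going by the values given here, the two numbers lie within the usual scatter of one another, so neither compound can be set apart from the other on this evidence, and no direct step between them is counted here.

Compound 3, `N#CC1CN1C(=O)Nc1ccc(C(F)(F)F)cc1`, is the not yet measured member of the set. It differs from compound 1 in one place: trifluoromethyl in place of fluoro on an aromatic carbon. Among the compounds with values here, no measured pair in this study shows what such an exchange does, so any forecast rests on the shared core alone. The author expects the step from compound 1 to compound 3 in this assay, a 1.3-fold lower number from compound 1 to compound 3 (0.12 log units; within the scatter), to be small, either way, and quite possibly within the scatter. For compound 3 in this assay the author estimates 1600 nM, with a range from 500 nM to 5000 nM.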

Compound 3, half-maximal inhibitory concentration: 1300 nM
Estimate against measurement, compound 3: 1.2-fold (0.09 log units) above, within the range that was stated.
By their numbers in this assay, from the lowest: compounds 3, 1 and 2 (each within the scatter of the next).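

Going by these compounds alone, the exchange of fluoro for trifluoromethyl, on an aromatic carbon para to a group of 8 heavy atoms, is the first change in this set that can be read as a single step. In this assay it is a 1.6-fold lower number from compound 1 to compound 3 (0.21 log units; within the scatter) and stays small, so on this evidence compound 1 and compound 3 cannot be set apart, even though the entering group has 4 heavy atoms where the leaving group has 1. This single step shows that a group of this size can stand at this position on the aromatic ring without a change beyond the scatter, but no measurement of a property of either group bears on the result, and the data offer no explanation for it.

The compounds shown leave open what an amine, a carboxylic acid, a methoxy group or a longer alkyl chain would do at this same position, and whether any of these would move the number beyond the scatter. They also leave open what happens when the nitrile on the shared core is replaced by a primary amide or a methyl ester, as all of the compounds shown keep the nitrile.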